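The source may hold more compounds than are shown below. What is called first, only, known or untested is meant among the compounds shown, and "the series" means these compounds.

Working notes on the series sharing the core of compound 1 `Fc1ccccc1-c1ccc2[nH]ncc2c1`.

Going by the values given here, in an assay on CHO-TREX cells for antagonist activity at transient receptor potential cation channel subfamily A member 1 (Homo sapiens), read by FLIPR and calcium flux, with a stated time of 10 min (on this read-out lower numbers stand for stronger inhibition and higher numbers for weaker inhibition), compound 1 gives 3950 nM, the highest number among the three compounds measured so far. Compound 2 `CCc1ccccc1-c1ccc2[nH]ncc2c1` gives 584 nM and compound 3 `FC(F)(F)Oc1ccccc1-c1ccc2[nH]ncc2c1` gives 3430 nM. The step of a 6.8-fold lower number from compound 1 to compound 2 (0.83 log units; beyond the scatter) is the only clear gain in the set; the step of a 1.2-fold lower number from compound 1 to compound 3 (0.06 log units; within the scatter) changes nothing beyond the scatter, and the step of a 5.9-fold higher number from compound 2 to compound 3 (0.77 log units; beyond the scatter) takes back what ethyl gave.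

Compound 4 `Fc1cccc(C(F)(F)F)c1-c1ccc2[nH]ncc2c1` differs from compound 1 by trifluoromethyl in place of hydrogen on an aromatic carbon; the fluoro group of compound 1 is kept. Among the compounds with values here, no measured step matches this change: each of the three measured steps replaces the fluoro group rather than adding a second group ortho to the group of 9 heavy atoms, so none bears on it directly. Within the data shown here, the only related information is that a larger group on this ring, ethyl in compound 2, gave the step of a 6.8-fold lower number from compound 1 to compound 2 (0.83 log units; beyond the scatter), while trifluoromethoxy in compound 3 gave none. A step of uncertain sign in this assay is therefore expected, most likely a small gain at best; the expected step is a 2.2-fold lower number from compound 1 to compound 4 (0.34 log units; beyond the scatter). For compound 4 the estimated value in this assay is 1800 nM, with an expected range from 450 nM to 7000 nM.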

Compound 4, half-maximal inhibitory concentration: 1230 nM
The estimate for compound 4 lay 1.5-fold (0.17 log units) above the measured number; the measured number falls inside the stated range.
By their numbers in this assay, from the lowest: compound 2; then compound 4; then compounds 3 and 1 (each within the scatter of the next).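

In this assay, trifluoromethyl on the aromatic carbon ortho to the group of 9 heavy atoms, with the fluoro group of compound 1 kept, gives a 3.2-fold lower number from compound 1 to compound 4 (0.51 log units; beyond the scatter). Going by these compounds alone, this is the first reading at this position: compounds 1, 2 and 3 all carry hydrogen there and differ only in the group that replaces fluoro, so they said nothing about adding a second group to this ring, whereas this step shows that a group of 4 heavy atoms is accepted here and that the number falls by more than the scatter. Nothing available explains why the number falls with this change.

From the compounds shown here alone, a single group at this position cannot show whether the gain depends on the size or the nature of that group, and what an amine, a carboxylic acid or a longer chain would do here remains open. Also open, going by these compounds, is whether the step holds without the fluoro group, or with ethyl in its place, the group that gave the largest gain among the replacements of fluoro.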